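A few compounds are considered here, and "the series" means these few. Any claim that something is new, unique, unknown or untested is made for them only; others in the source may bear on it.

In a functional assay on SGC-7901 cells (Homo sapiens) for cytotoxicity, read by MTT assay, with a stated time of 48 h (on this read-out lower numbers stand for stronger inhibition and higher numbers for weaker inhibition), two compounds sharing one core have been measured so far. Compound 1 (`O=C(CSc1ccc(Br)cc1)N1N=C(c2cc3ccccc3oc2=O)C[C@@H]1c1ccc(C(F)(F)F)cc1`) gives 12100 nM, and compound 2 (`O=C(CSc1ncccn1)N1N=C(c2cc3ccccc3oc2=O)C[C@@H]1c1ccc(C(F)(F)F)cc1`) gives 4390 nM, the lower of the two numbers. Compound 3 (`O=C(CSCc1ccco1)N1N=C(c2cc3ccccc3oc2=O)C[C@@H]1c1ccc(C(F)(F)F)cc1`) has not yet been measured. It differs from compound 2 by (furan-2-yl)methyl in place of pyrimidin-2-yl on a sulfur, with (furan-2-yl)methyl in place of pyrimidin-2-yl on a sulfur. Within the data shown here, no measured compound carries (furan-2-yl)methyl, so the data offer no direct reading of this group. Among the measured compounds shown here, the only measured step at that sulfur puts pyrimidin-2-yl in place of 4-bromophenyl. Because of a 2.8-fold lower number from compound 1 to compound 2 (0.44 log units; beyond the scatter) a change of comparable or smaller size is expected in this assay. For the measured compounds named here, the direction is uncertain, but a move towards a higher number seems the more likely, as compound 2 holds the lower of only two values. The expected change is a 1.4-fold higher number from compound 2 to compound 3 (0.14 log units; within the scatter). For compound 3 the estimated value is 6000 nM, with an expected range of 2200 nM to 16000 nM.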

Compound 3, half-maximal inhibitory concentration: 9740 nM
Compound 3: middle estimate off by 1.6-fold (0.21 log units), on the low side; the measured number falls inside the stated range.
By their numbers in this assay, from the lowest: compound 2; then compounds 3 and 1 (each within the scatter of the next).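

In this assay, the step with (furan-2-yl)methyl in place of pyrimidin-2-yl on the sulfur is a 2.2-fold higher number from compound 2 to compound 3 (0.35 log units; beyond the scatter) and shows that a second group of the same heavy-atom count does not keep the lower number of compound 2. The step with (furan-2-yl)methyl in place of 4-bromophenyl is a 1.2-fold lower number from compound 1 to compound 3 (0.09 log units; within the scatter) and leaves these two groups unresolved in this assay, even though one carries a five-membered aromatic ring and the other a para-free description of a phenyl ring is all the data give, so among these three compounds only compound 2 stands apart, with its steps to both others beyond the scatter. No available evidence explains why pyrimidin-2-yl differs from the other two groups at this sulfur.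

The change from compound 2 to compound 3 swaps the ring and also adds a methyl link to the sulfur, so the compounds shown do not separate these two differences. Going by these compounds, a furan-2-yl or pyridin-2-yl group set directly on the sulfur, or a benzyl group, would address this, and the effect of an amine or a carboxylic acid at this position remains open.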